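Methoxyphenyl variation in a small series

This account rests on a few compounds, and the source may have more. Where it says the series, first, only, none or still open, it means among the compounds named here.

Measured so far:
compound 1, `COc1ccc(-c2cc3cc(C4C(C#N)=C(N)OC5=C4C(=O)CC(C)(C)C5)cc(C(C)C)c3oc2=O)cc1`, 64.9%
compound 2, `COc1ccc(-c2cc3cc(C4C(C#N)=C(N)OC5=C4C(=O)CC(C)(C)C5)cc(C)c3oc2=O)cc1OC`, 10.4%
compound 3, `COc1cc(-c2cc3cc(C4C(C#N)=C(N)OC5=C4C(=O)CCC5)cc(C(C)C)c3oc2=O)cc(OC)c1OC`, 31.9%

All three were tested in a functional assay on the whole organism (strain Swiss albino) with Mus musculus as the target, in the forced swim test, with a stated time of 5 min, at a dose of 0.5 mg/kg by the intraperitoneal route; on this read-out lower numbers stand for less inhibition and higher numbers for more inhibition at the one dose given (going by the name of the read-out). Compound 1 gives 64.9%, the highest of the three numbers; compound 3 stands nearest, lower by a margin beyond the scatter, and compound 2 stands furthest, also beyond the scatter. Among the measured compounds shown here, compound 2 and compound 3 each differ from compound 1 in more than one place, so no single isolated step among the measured compounds is available.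

Compound 4, `COc1cc(-c2cc3cc(C4C(C#N)=C(N)OC5=C4C(=O)CC(C)(C)C5)cc(C(C)C)c3oc2=O)cc(OC)c1OC`, is not yet measured. It differs from compound 1 in one place: 3,4,5-trimethoxyphenyl in place of 4-methoxyphenyl on an aromatic carbon. Compound 3 carries the same 3,4,5-trimethoxyphenyl group as compound 4 but differs from it in the shared core, and compound 3 gives 31.9% in this assay, below compound 1. Compound 2, with another methoxy pattern and another core variant, gives 10.4%. Both companions of compound 1 sit lower. The step from compound 1 to compound 4 is therefore expected to go downward, beyond the scatter, a number 24.9 percentage points lower from compound 1 to compound 4 (beyond the scatter). Compound 4 is estimated at 40%, with a range from 20% to 60%. For the measured compounds named here, the range is wide; the only compound sharing the entering group, compound 3, also differs in the core.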

Compound 4, a percentage reported as inhibition, in the whole organism at one dose (the size of the read-out at that dose, not a potency): 29.2%
Compound 4: middle estimate off by 10.8 percentage points, on the high side; low and high end bracket the measured number.
By their numbers in this assay, from the lowest: compound 2; then compounds 4 and 3 (each within the scatter of the next); then compound 1.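

In this assay, replacing 4-methoxyphenyl with 3,4,5-trimethoxyphenyl on the aromatic carbon, with the rest of compound 1 unchanged, gives a number 35.7 percentage points lower from compound 1 to compound 4 (beyond the scatter). Among the compounds shown here, this is the only isolated change, and it shows that the read-out responds to the aryl group at this position, which the earlier compounds could not show because each differed from compound 1 in more than one place. No measurement is available to explain the size or direction of this step.

From the compounds shown here alone, with a single pair at this position, it remains open whether the step follows the number of methoxy groups on the aryl ring or depends on the particular 3,4,5-trimethoxyphenyl arrangement. The compounds shown also leave open how an unsubstituted phenyl group, or a phenyl group carrying a dimethylamino group or a carboxylic acid in place of the methoxy group, would read at this position on the core of compound 1.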